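The source may report more compounds than this note shows. Statements on the series, on what has been measured and on what is new or still open speak of the compounds shown alone.

Working notes on the series, read in a functional assay (plasma) for inhibition, with Canis familiaris (Canis lupus familiaris) as the target; a higher number here means a weaker inhibitor, a lower number a stronger inhibitor. Compound 1 `CC(=O)N[C@@H]1CSSC(C)(C)[C@H](C(N)=O)NC(=O)[C@H](CC(=O)O)NC(=O)CNC(=O)[C@@H](CCCN=C(N)N)NC1=O` reads > 200000 nM, which is a limit of the assay and not a number. For the measured compounds named here, compound 2 `CC(=O)N[C@H]1CSSC(C)(C)[C@H](C(N)=O)NC(=O)[C@@H](CC(=O)O)NC(=O)CNC(=O)[C@@H](CCCN=C(N)N)NC1=O` gives 98700 nM, the only true number so far, so its standing rests on a single comparison with compound 1.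

Compound 3 `CC(=O)N(C)[C@H]1CSSC(C)(C)[C@H](C(N)=O)NC(=O)[C@@H](CC(=O)O)NC(=O)CNC(=O)[C@@H](CCCN=C(N)N)NC1=O` carries methyl in place of hydrogen on an amide-type nitrogen, the acetamido becoming acetyl(methyl)amino: methyl in place of hydrogen on an amide-type nitrogen.

Going by the values given here, only one measured step exists, an at least 2.0-fold lower number from compound 1 to compound 2 (0.30 log units; that floor lies within the scatter). It bears on this change only indirectly, as its size is bounded by the limit of > 200000 nM in this assay, at which 1 of the 2 values shown sits, and its structural content is the fact that compounds 1 and 2 differ only in the configuration as drawn. Among the compounds with values here, no measured step places a methyl on this nitrogen or on any other, so no size can be carried over from the series. With no direction supported by the data, the working expectation in this assay is no change beyond the scatter, held with wide uncertainty. The expected 1.2-fold higher number from compound 2 to compound 3 (0.08 log units; within the scatter) is an estimate of that kind. For compound 3 the estimated value is 120000 nM, with an expected range of 35000 nM to 280000 nM.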

Compound 3, half-maximal inhibitory concentration: 1900 nM
The estimate for compound 3 lay 63-fold (1.80 log units) above the measured number; measured number below the stated range.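

In this assay, for the compounds shown here, methyl in place of hydrogen on the amide-type nitrogen, the acetamido becoming acetyl(methyl)amino, gives a 52-fold lower number from compound 2 to compound 3 (1.72 log units; beyond the scatter), the first step that is beyond the scatter. This position, on a nitrogen whose other neighbours are a carbonyl carbon and a saturated ring carbon, is therefore one where a single added carbon moves the read-out strongly, whereas the earlier step, an at least 2.0-fold lower number from compound 1 to compound 2 (0.30 log units; that floor lies within the scatter), changed only configuration and gave a floor within the scatter. Nothing in the data accounts for the size of the new step, neither the configuration nor the assay limit bearing on this change.

From the compounds shown here alone, it remains open whether the effect is specific to methyl or continues with ethyl or a longer chain on this same nitrogen, and whether a ring-forming group such as an azetidine at this place would keep it. Also open, going by these compounds, is whether the same methyl would act alike in the configuration of compound 1, or on the other amide nitrogens of the shared core.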